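Changing the Sulfonyl Substituent Between Compound 1 and Compound 4

The source may report more compounds than this note shows. Statements on the series, on what has been measured and on what is new or still open speak of the compounds shown alone.

Of the compounds shown here, three have been measured in an assay on CHO cells for displacement of a labelled ligand from prostaglandin D2 receptor 2 (Homo sapiens), read by scintillation counting; on this read-out higher numbers stand for weaker inhibition and lower numbers for stronger inhibition. Compound 1 `Cc1ccc(S(=O)(=O)N2CCN(C)CC2)cc1C#Cc1cc(Cl)ccc1OCC(=O)O` gives 21 nM and stands second highest of the three numbers. Compound 2 `CS(=O)(=O)Cc1cccc(C#Cc2cc(Cl)ccc2OCC(=O)O)c1` gives 48 nM, a higher number that lies beyond the scatter. Compound 3 `COc1ccc(-c2ccc(C#Cc3cc(Cl)ccc3OCC(=O)O)cc2S(C)(=O)=O)cc1` gives 7 nM, a lower number that also lies beyond the scatter. Compound 4 `Cc1ccc(S(=O)(=O)N(C)CC(C)C)cc1C#Cc1cc(Cl)ccc1OCC(=O)O` has not yet been measured in this assay. It differs from compound 1 in one place: isobutyl(methyl)amino in place of 4-methylpiperazin-1-yl on a sulfonyl sulfur. Among the compounds with values here, no measured pair shows what such a change on the sulfonyl sulfur does, so the direction is open. The step of a 1.2-fold higher number from compound 1 to compound 4 (0.08 log units; within the scatter) is expected to stay within the scatter. The estimate for compound 4 is 25 nM, with a range from 8 nM to 80 nM.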

Compound 4, inhibition constant: 4.2 nM
Estimate against measurement, compound 4: 6.0-fold (0.77 log units) above, outside the stated range (below it).
By their numbers in this assay, from the lowest: compounds 4 and 3 (each within the scatter of the next); then compound 1; then compound 2.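

Within the data shown here, on the sulfonyl sulfur, isobutyl(methyl)amino in place of 4-methylpiperazin-1-yl gives a 5.0-fold lower number from compound 1 to compound 4 (0.70 log units; beyond the scatter) in this assay and so shows that the group at this position changes the read-out, which no earlier pair could show. An open chain with no ring is not only accepted here but gives the stronger inhibition of this pair. Nothing available explains this step. Whether the ring, the second nitrogen or the isobutyl chain accounts for it remains open from this single pair. A piperidin-1-yl ring or a dimethylamino group on the same sulfur would help to separate these.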